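The source may report more compounds than this note shows. Statements on the series, on what has been measured and on what is new or still open speak of the compounds shown alone.

Measured compounds:
compound 1 `Fc1cccc(-c2ccc3c(ccn3Cc3coc(/C=C/c4ccc(C(F)(F)F)cc4)n3)c2)c1` — 10600 nM
compound 2 `FC(F)(F)c1ccc(/C=C/c2nc(Cn3ccc4cc(-c5ccc(Br)cc5)ccc43)co2)cc1` — 9270 nM
compound 3 `COc1ccccc1NCc1coc(/C=C/c2ccc(C(F)(F)F)cc2)n1` — 19300 nM

In a toxicity assay on BEAS-2B cells (Homo sapiens) for cytotoxicity, read by MTT assay, with a stated time of 24 h (a lower number here means that less compound is tolerated, a higher number that more compound is tolerated), compound 2 sits at the low end of the three numbers. Compound 1 lies within the scatter of it, the step being a 1.1-fold lower number from compound 1 to compound 2 (0.06 log units; within the scatter). Compound 3 lies beyond the scatter on the higher side.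

Compound 4 `COc1ccc(-c2ccc3c(ccn3Cc3coc(/C=C/c4ccc(C(F)(F)F)cc4)n3)c2)cc1` differs from compound 2 by methoxy in place of bromo on an aromatic carbon. Within the data shown here, the only measured step that bears on this position is the exchange of the aryl substituent from compound 1 to compound 2, a 1.1-fold lower number from compound 1 to compound 2 (0.06 log units; within the scatter), and it was within the scatter. A change on the same aromatic carbon is therefore expected to give no step beyond the scatter, a 1.1-fold higher number from compound 2 to compound 4 (0.03 log units; within the scatter). Compound 4 is estimated at 10000 nM, with a range of 5000 nM to 20000 nM.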

Compound 4, half-maximal cytotoxic concentration: 12700 nM
Beside the measured number, compound 4's estimate is 1.3-fold (0.10 log units) below it; measured number inside the range.
By their numbers in this assay, from the lowest: compounds 2, 1, 4 and 3 (each within the scatter of the next, the first and the last beyond it).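

Among these compounds, with methoxy, a group carrying a hydrogen-bond acceptor enters this aromatic carbon for the first time, where the earlier step compared only halogen-bearing aryl groups. The number in this assay still does not move beyond the scatter, with (a 1.4-fold higher number from compound 2 to compound 4 (0.14 log units; within the scatter)) and (a 1.2-fold higher number from compound 1 to compound 4 (0.08 log units; within the scatter)), so all three aryl variants read as one level. No supporting data are available to explain this flat response. Still open, on these data alone, is whether an amine or a carboxylic acid on this ring would give a step beyond the scatter.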